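The source may hold more compounds than are shown below. What is called first, only, known or untested is meant among the compounds shown, and "the series" means these compounds.

Compound 1 `O=C(Nc1cccc(-n2cc(-c3ccncc3)c(-c3ccc(Cl)c(O)c3)n2)c1)Nc1cccc(C(F)(F)F)c1` is the weaker of the two compounds measured in a functional assay on MDA-MB-435 cells (Homo sapiens) for inhibition, read by sulforhodamine B assay, with a stated time of 48 h (a higher number here means a weaker inhibitor of growth, a lower number a stronger inhibitor of growth), where compound 1 gives 1490 nM. Among the compounds with values here, its nearest neighbour is compound 2 `COc1cc(-c2nn(-c3cccc(NC(=O)Nc4cccc(C(F)(F)F)c4)c3)cc2-c2ccncc2)ccc1Cl`, which in this assay gives 866 nM; the only measured step, a 1.7-fold lower number from compound 1 to compound 2 (0.24 log units; within the scatter), concerns methyl in place of hydrogen on an oxygen on an aromatic ring of the shared core and stays within the scatter.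

Compound 3 `O=C(Nc1cccc(-n2cc(-c3ccncc3)c(-c3ccc(Cl)c(O)c3)n2)c1)Nc1ccc(Cl)c(C(F)(F)F)c1` differs from compound 1 by chloro in place of hydrogen on an aromatic carbon. Within the data shown here, no measured step touches the ring that carries the trifluoromethyl group, so nothing measured bears directly on this change. Among the measured compounds shown here, the one step on record, small as it is, gives no sign that the series moves much on single substituent changes. A step within the scatter is therefore expected, a 1.2-fold lower number from compound 1 to compound 3 (0.09 log units; within the scatter), and compound 3 is estimated at 1200 nM in this assay, with a range from 500 nM to 3000 nM.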

Compound 3, concentration for 50% growth inhibition: 660 nM
The estimate for compound 3 lay 1.8-fold (0.26 log units) above the measured number, within the range that was stated.
By their numbers in this assay, from the lowest: compounds 3, 2 and 1 (each within the scatter of the next, the first and the last beyond it).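

In this assay, within the data shown here, chloro in place of hydrogen on the ring carrying trifluoromethyl gives a 2.3-fold lower number from compound 1 to compound 3 (0.35 log units; beyond the scatter), the first step to lie beyond the scatter. The earlier step, a 1.7-fold lower number from compound 1 to compound 2 (0.24 log units; within the scatter), concerned the other end of the molecule and stayed within the scatter, so this aromatic carbon, ortho to a trifluoromethyl group and para to a large group, is the one place shown so far where a single substitution moves the number, though only modestly. No available evidence gives a reason for this step.

The compounds shown leave open whether the step is specific to chloro or would also appear with fluoro, methyl, methoxy or an amine at this carbon. Also open, going by these compounds, is whether the same chloro step would hold on the methoxy core of compound 2.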